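Swapping the aryl group in a series of cinnamoyl hydrazides

A few compounds are considered here, and "the series" means these few. Any claim that something is new, unique, unknown or untested is made for them only; others in the source may bear on it.

Measured compounds:
compound 1 `COc1ccc(/C=C/C(=O)NNC(=O)c2ccc3c(c2)OCCO3)cc1`: 930 nM
compound 2 `O=C(/C=C/c1cccc(Cl)c1)NNC(=O)c1ccc2c(c1)OCCO2`: 3560 nM
compound 3 `O=C(/C=C/c1cccc(Br)c1)NNC(=O)c1ccc2c(c1)OCCO2`: 3330 nM

All three share one core and differ only in the aryl group carried on a double-bonded chain carbon. In a functional assay on cells (Cancer cell lines, Homo sapiens) for inhibition, read by MTT assay, with a stated time of 48 h (a lower number here means a stronger inhibitor, a higher number a weaker inhibitor), compound 1 gives the lowest number of the three. Compound 4 `O=C(/C=C/c1cccc(F)c1)NNC(=O)c1ccc2c(c1)OCCO2` is not yet measured; relative to compound 1 it differs by 3-fluorophenyl in place of 4-methoxyphenyl on a double-bonded chain carbon bound to a double-bonded chain carbon.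

For the measured compounds named here, two measured steps bear on this change. Replacing the same group by a 3-chlorophenyl gave a 3.8-fold higher number from compound 1 to compound 2 (0.58 log units; beyond the scatter), and by a 3-bromophenyl gave a 3.6-fold higher number from compound 1 to compound 3 (0.55 log units; beyond the scatter). Between those two halogens the difference was a 1.1-fold lower number from compound 2 to compound 3 (0.03 log units; within the scatter). A third halogen at the same position is therefore expected to weaken inhibition by a similar amount, giving an expected step of a 3.2-fold higher number from compound 1 to compound 4 (0.51 log units; beyond the scatter). For compound 4 the expected value is 3000 nM, with a range of 1400 nM to 6500 nM.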

Compound 4, half-maximal inhibitory concentration: 4110 nM
Estimate against measurement, compound 4: 1.4-fold (0.14 log units) below, and the stated range covers the measured number.
By their numbers in this assay, from the lowest: compound 1; then compounds 3, 2 and 4 (each within the scatter of the next).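

Fluoro, the third halogen tried here, sits level with the other two, with a 1.2-fold higher number from compound 3 to compound 4 (0.09 log units; within the scatter) and a 1.2-fold higher number from compound 2 to compound 4 (0.06 log units; within the scatter), so swapping the halogen among compound 2, compound 3 and compound 4 changes nothing readable. The weaker result on leaving the 4-methoxyphenyl group, a 4.4-fold higher number from compound 1 to compound 4 (0.65 log units; beyond the scatter), therefore holds for all three halogens. Nothing measured here gives a cause for this.

The substituent and its ring position change together from compound 1 to these halogen compounds, so their contributions remain unseparated. A 3-methoxyphenyl or 4-fluorophenyl group would pull them apart.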